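The source may report more compounds than this note shows. Statements on the series, on what has been measured and on what is new or still open speak of the compounds shown alone.

Results so far in a functional assay on A549 cells (Homo sapiens) for cytotoxicity, read by MTT assay, with a stated time of 72 h; on this read-out higher numbers stand for weaker inhibition and lower numbers for stronger inhibition

- compound 1 `CNC(=O)c1cc(Oc2ccc(C3=NNC(c4ccc([N+](=O)[O-])cc4)C3)cc2)ccn1` gives 19500 nM
- compound 2 `CNC(=O)c1cc(Oc2ccc(C3=NNC(c4ccccc4)C3)cc2)ccn1` gives 8600 nM
- compound 3 `CNC(=O)c1cc(Oc2ccc(C3CC(c4ccc([N+](=O)[O-])cc4)=NN3)cc2)ccn1` gives "not determined" (no result reported)

Compound 3 offers no number to start from, since its result stands as "not determined" (no result reported) and nothing can be counted from it. Compound 4 `CNC(=O)c1cc(Oc2ccc(C3CC(c4ccc(Cl)cc4)=NN3)cc2)ccn1` changes one group of compound 3: chloro in place of nitro on an aromatic carbon, in short, chloro in place of nitro on an aromatic carbon. For the measured compounds named here, only one measured step also removes a nitro group, namely a 2.3-fold lower number from compound 1 to compound 2 (0.36 log units; beyond the scatter), and there hydrogen enters, not chloro, so it is a loose guide. No step size or direction can therefore be expected in this assay, only a level similar to that of the two measured compounds. The estimated value for compound 4 is 10000 nM, with an expected range from 3500 nM to 30000 nM.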

Compound 4, half-maximal inhibitory concentration: 20500 nM
Estimate against measurement, compound 4: 2.1-fold (0.31 log units) below; the measured number falls inside the stated range.
By their numbers in this assay, from the lowest: compound 2; then compounds 1 and 4 (each within the scatter of the next).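

For the compounds shown here, the swap from compound 3 to compound 4 gives no step that can be read: compound 3 carries no number. What the change from 4-nitrophenyl to 4-chlorophenyl does in this assay stays open, and no evidence on hand explains these values.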